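A Cyano Group Enters the Sulfonyl Phenyl Ring

A few compounds are considered here, and "the series" means these few. Any claim that something is new, unique, unknown or untested is made for them only; others in the source may bear on it.

Of the compounds shown here, two on a shared core have been measured in an assay on isolated protein for displacement of a labelled ligand from metabotropic glutamate receptor 5 (Homo sapiens), with a stated time of 60 min, tested at 1 uM; on this read-out lower numbers stand for less inhibition and higher numbers for more inhibition at the one concentration tested (going by the name of the read-out). Compound 1 `Cc1ccc(S(=O)(=O)c2cnc3cc(Cl)ccc3c2N2CCC(C)CC2)cc1F` carries a 3-fluoro-4-methylphenyl group on the sulfonyl sulfur, and in this assay compound 1 gives 85%. Compound 2 `CC1CCN(c2c(S(=O)(=O)c3ccccc3)cnc3cc(Cl)ccc23)CC1` carries a plain phenyl there instead, and in this assay compound 2 gives 93%. Among the measured compounds shown here, the only step measured so far, a number 8 percentage points higher from compound 1 to compound 2 (within the scatter), shows that swapping the substituted phenyl for the bare phenyl leaves the read-out essentially unchanged. Compound 2 thus stands at the top of the two numbers, with compound 1 close behind and within the scatter of it.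

Compound 3 `CC1CCN(c2c(S(=O)(=O)c3ccc(C#N)cc3)cnc3cc(Cl)ccc23)CC1` is the next compound, not yet measured. It differs from compound 2 in one place: cyano in place of hydrogen on an aromatic carbon. Read one bond further out, the change is phenyl to 4-cyanophenyl. For the measured compounds named here, the one measured step bears on this only loosely, since it tells that a substituent on that phenyl ring left the number in this assay level, without a shift beyond the scatter. On that basis the expected step of a number 7 percentage points lower from compound 2 to compound 3 (within the scatter) is small or absent, and compound 3 is estimated to give 86% in this assay, within a range from 66% to 98%.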

Compound 3, a percentage reported as inhibition, at one concentration (the size of the read-out at that concentration, not a potency): 70%
Compound 3: middle estimate off by 16 percentage points, on the high side; measured number inside the range.
By their numbers in this assay, from the lowest: compound 3; then compounds 1 and 2 (each within the scatter of the next).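

In this assay the sulfonyl phenyl ring proves sensitive to what it carries: cyano in place of hydrogen, on an aromatic carbon para to a large group, gives a number 23 percentage points lower from compound 2 to compound 3 (beyond the scatter) and so moves the read-out by more than the earlier step between the plain phenyl and the 3-fluoro-4-methylphenyl compounds did. Exchanging the 3-fluoro-4-methylphenyl group for 4-cyanophenyl also gives a number 15 percentage points lower from compound 1 to compound 3 (beyond the scatter) and the ring with the cyano group therefore stands apart from both earlier rings, so a substituent on this ring is not harmless by default, though the size of the drop is modest. Nothing available here offers a reason for this drop.

Going by these compounds, it remains open whether the loss belongs to the cyano group alone or would also appear with a different group on the same carbon, such as a methoxy group, a chlorine atom or a carboxylic acid. On these data alone, a percentage at one concentration is also not a potency, so how much binding strength the change costs remains unknown.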